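Swapping the Pyridine Ring for a Fluorophenyl Group

A few compounds are considered here, and "the series" means these few. Any claim that something is new, unique, unknown or untested is made for them only; others in the source may bear on it.

Measured in a functional assay on MGC-803 cells (Homo sapiens) for antiproliferative activity, read by CCK-8 assay, with a stated time of 72 h, tested at 2 uM; on this read-out higher numbers stand for a stronger effect at the one concentration tested and lower numbers for a weaker effect:
Compound 1 `Nc1ccccc1NC(=O)c1ccc(CSC(=S)N2CCN(Cc3ccccn3)CC2)cc1`: 23.4%
Compound 2 `COc1ccc(N2CCN(C(=S)SCc3ccc(C(=O)Nc4ccccc4N)cc3)CC2)cc1`: 25.3%
Compound 3 `Nc1ccccc1NC(=O)c1ccc(CSC(=S)N2CCN(c3ccncc3)CC2)cc1`: 64.8%

Compound 3 gives the highest number of the three, and both steps toward it are large: a number 41.4 percentage points higher from compound 1 to compound 3 (beyond the scatter) and a number 39.5 percentage points higher from compound 2 to compound 3 (beyond the scatter). Compound 4 `Nc1ccccc1NC(=O)c1ccc(CSC(=S)N2CCN(c3ccccc3F)CC2)cc1` differs from compound 3 in one place: 2-fluorophenyl in place of pyridin-4-yl on an amine nitrogen in a ring. The step from compound 2 to compound 3 bears most on this change, since compound 2 also carries a six-membered ring of carbon only on that ring nitrogen, and compound 3 gained strongly over it. Going the other way, to a carbon-only ring, is therefore expected to lose much of that gain, so a large downward step a number 32.8 percentage points lower from compound 3 to compound 4 (beyond the scatter) is expected. Compound 4 is estimated at 32%, within 15% to 55%.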

Compound 4, a percentage reported as inhibition, at one concentration (the size of the read-out at that concentration, not a potency): 33.7%
Estimate against measurement, compound 4: 1.7 percentage points below; low and high end bracket the measured number.
By their numbers in this assay, from the lowest: compounds 1, 2 and 4 (each within the scatter of the next, the first and the last beyond it); then compound 3.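

On this ring nitrogen, 2-fluorophenyl does not hold what pyridin-4-yl gives (a number 31.1 percentage points lower from compound 3 to compound 4 (beyond the scatter)). Compound 4 instead stays level with the 4-methoxyphenyl compound (a number 8.4 percentage points higher from compound 2 to compound 4 (within the scatter)) and only modestly clear of the (pyridin-2-yl)methyl compound (a number 10.3 percentage points higher from compound 1 to compound 4 (beyond the scatter)), so both carbon-only rings shown fall well short of compound 3. No evidence here says what lies behind this drop.

Still open, going by these compounds, is whether pyridin-4-yl depends on where its ring nitrogen sits, which pyridin-3-yl could test. Plain phenyl, without fluorine, would show what the fluorine in compound 4 contributes.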